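Propylamino to (ethylamino)methyl on a short amine chain

The source may report more compounds than this note shows. Statements on the series, on what has been measured and on what is new or still open speak of the compounds shown alone.

Compound 1 `CCNCCCNCCCN` gives > 100000 nM as a limit of the assay.
Compound 2 `CCCNCCCNCCCN` gives 100000 nM as a number.
Compound 3 `CCCNCCCNCCCNCCC` gives 60000 nM as a number.

For the measured compounds named here, in a functional assay on L1210 cells (Mus musculus) for inhibition, with a stated time of 96 h (on this read-out higher numbers stand for weaker inhibition and lower numbers for stronger inhibition), compound 2 gives 100000 nM and its one neighbour with a number is compound 3 at 60000 nM, the two lying within the scatter of each other. Compound 1 is known only as a limit, > 100000 nM, and nothing more can be read from it. That leaves a number no higher from compound 1 to compound 2 (the limit leaves the size open) for methyl in place of hydrogen on a saturated chain carbon, two bonds along the chain from an amine nitrogen.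

The next compound to be measured is compound 4 `CCNCCCCNCCCN`, which has the same atoms as compound 2, joined differently: (ethylamino)methyl in place of propylamino on a saturated chain carbon, three bonds along the chain from an amine nitrogen. In words, (ethylamino)methyl stands in place of propylamino on a saturated chain carbon, three bonds along the chain from an amine nitrogen. Neither measured step is this same change. The only one with a readable size, a 1.7-fold lower number from compound 2 to compound 3 (0.22 log units; within the scatter), is small, so no step beyond the scatter is expected in this assay. The expected step is a 1.1-fold lower number from compound 2 to compound 4 (0.05 log units; within the scatter) and no more. For compound 4 the estimated value is 90000 nM, with an expected range from 35000 nM to 200000 nM.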

Compound 4, half-maximal inhibitory concentration: 40000 nM
Compound 4: the middle estimate sits 2.3-fold (0.35 log units) above what was measured; the range from low to high includes it.
By their numbers in this assay, from the lowest: compounds 4, 3 and 2 (each within the scatter of the next, the first and the last beyond it).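

In this assay, for the compounds shown here, (ethylamino)methyl in place of propylamino on a saturated chain carbon, three bonds along the chain from an amine nitrogen, gives a 2.5-fold lower number from compound 2 to compound 4 (0.40 log units; beyond the scatter), the first step of readable size to lie beyond the scatter. The two compounds have the same atoms, joined differently, and the groups that swap match in their counts of heavy atoms, donors and acceptors, so this step comes with a new connection of the atoms and no added atom. With (ethylamino)methyl in place of ethylamino at the same position, the result is an at least 2.5-fold lower number from compound 1 to compound 4 (0.39 log units; beyond the scatter), but the size of this step is open-ended, as compound 1 is known only from a limit of the assay: the limit of > 100000 nM in this assay, at which 1 of the 4 values shown sits.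

The compounds shown leave open whether a longer chain at this position, such as (propylamino)methyl or (butylamino)methyl, would take the number further in the same direction. They also leave open whether the same change would give a step of similar size on a compound with a propyl on the amine nitrogen, as in compound 3, or with a hydroxyl at the chain end.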